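The source may report more compounds than this note shows. Statements on the series, on what has been measured and on what is new or still open speak of the compounds shown alone.

Compound 3 `CCCS(=O)(=O)Nc1ccc(F)c(C(=O)c2n[nH]c3ncc(-c4cccc([N+](=O)[O-])c4)cc23)c1F` stands at the top of the three numbers in an assay for binding affinity to dual specificity mitogen-activated protein kinase kinase 4 (Homo sapiens), read by KINOMEscan, tested at 100 nM (a lower number here means a stronger effect, a higher number a weaker effect of the compound at the concentration tested), giving 15%. Compound 2 `CCCS(=O)(=O)Nc1ccc(F)c(C(=O)c2n[nH]c3ncc(-c4ccc(N(C)C)cc4)cc23)c1F` gives 2.5%, and compound 1 `CCCS(=O)(=O)Nc1ccc(F)c(C(=O)c2n[nH]c3ncc(-c4ccccc4)cc23)c1F` gives 2.4%. Replacing hydrogen with dimethylamino on the aromatic carbon produced a number 0.1 percentage points higher from compound 1 to compound 2 (within the scatter), while placing nitro there produced a number 12.6 percentage points higher from compound 1 to compound 3 (beyond the scatter), and swapping the 4-(dimethylamino)phenyl for 3-nitrophenyl produced a number 12.5 percentage points higher from compound 2 to compound 3 (beyond the scatter).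

Compound 4 `CCCS(=O)(=O)Nc1ccc(F)c(C(=O)c2n[nH]c3ncc(-c4ccc(S(=O)(=O)NCC)cc4)cc23)c1F` differs from compound 3 as follows: 4-(ethylsulfamoyl)phenyl in place of 3-nitrophenyl on an aromatic carbon. The step bearing most directly on this change is a number 12.5 percentage points higher from compound 2 to compound 3 (beyond the scatter), which shows that leaving the 3-nitrophenyl for a differently substituted phenyl can lower the number by a modest amount, and a number 0.1 percentage points higher from compound 1 to compound 2 (within the scatter) shows a substituted phenyl can sit at the level of the plain phenyl of compound 1. Compound 4 is therefore expected to move back down, with an estimated step of a number 10 percentage points lower from compound 3 to compound 4 (within the scatter), beyond the scatter. The estimate for compound 4 in this assay is 5%, within a range from 1% to 15%.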

Compound 4, a percentage reported as activity, at one concentration (the size of the read-out at that concentration, not a potency): 3%
Estimate against measurement, compound 4: 2 percentage points above; the range from low to high includes it.
By their numbers in this assay, from the lowest: compounds 1, 2 and 4 (each within the scatter of the next); then compound 3.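

In this assay, 4-(ethylsulfamoyl)phenyl in place of 3-nitrophenyl gave a number 12 percentage points lower from compound 3 to compound 4 (beyond the scatter), while ethylsulfamoyl in place of dimethylamino gave a number 0.5 percentage points higher from compound 2 to compound 4 (within the scatter), and ethylsulfamoyl in place of hydrogen gave a number 0.6 percentage points higher from compound 1 to compound 4 (within the scatter). This position therefore takes a phenyl carrying the ethylsulfamoyl group, with its hydrogen-bond donor, without separating from the plain phenyl or the 4-(dimethylamino)phenyl, and compound 3 alone stands apart among the four. Nothing available explains this difference.

The compounds shown leave open whether the separation of compound 3 follows the nitro group itself or its place on the phenyl, a question that 4-nitrophenyl or 3-(ethylsulfamoyl)phenyl would address. Also open, going by these compounds, is how a carboxylic acid or a longer chain on the sulfamoyl nitrogen would read here.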